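A few compounds are considered here, and "the series" means these few. Any claim that something is new, unique, unknown or untested is made for them only; others in the source may bear on it.

Working notes on the series in an assay on isolated protein for displacement of a labelled ligand from metabotropic glutamate receptor 5 (Homo sapiens), with a stated time of 60 min, tested at 1 uM; on this read-out higher numbers stand for more inhibition at the one concentration tested (going by the name of the read-out) and lower numbers for less inhibition. Compound 1, `Cc1ccc2ncc(S(=O)(=O)c3ccc(F)cc3)c(N3CCC(C)CC3)c2c1`, gives 90%. Compound 2, `COc1ccc(S(=O)(=O)c2cnc3ccc(C)cc3c2N2CCC(C)CC2)cc1`, gives 62%. Compound 3, `COc1ccc2ncc(S(=O)(=O)c3cc(C)cc(C)c3)c(N3CCC(C)CC3)c2c1`, gives 79%. Compound 3 thus stands second of the three: compound 1 lies higher, beyond the scatter, and compound 2 lies lower, beyond the scatter. Among the measured compounds shown here, the one single-point step measured so far is a number 28 percentage points lower from compound 1 to compound 2 (beyond the scatter), methoxy in place of fluoro on an aromatic carbon of the ring bearing the sulfonyl group.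

Compound 4, `Cc1cc(C)cc(S(=O)(=O)c2cnc3ccc(C)cc3c2N2CCC(C)CC2)c1`, differs from compound 3 as follows: methyl in place of methoxy on an aromatic carbon. For the measured compounds named here, no measured step covers a methoxy-to-methyl swap, and the change sits on the fused core rather than on the sulfonyl-bearing ring, so the step from compound 1 to compound 2 bears on it only loosely; it shows that exchanging a small substituent for methoxy moved this assay modestly. Compound 4 is therefore expected to move from compound 3 by a number 3 percentage points higher from compound 3 to compound 4 (within the scatter), a small upward step at most, with the outcome estimated at 82% in a range from 65% to 95%.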

Compound 4, a percentage reported as inhibition, at one concentration (the size of the read-out at that concentration, not a potency): 80%
Compound 4: middle estimate off by 2 percentage points, on the high side; the range from low to high includes it.
By their numbers in this assay, from the lowest: compound 2; then compounds 3, 4 and 1 (each within the scatter of the next, the first and the last beyond it).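

In this assay the swap of methoxy for methyl on the aromatic carbon of the shared core gives a number 1 percentage points higher from compound 3 to compound 4 (within the scatter) and so does not separate the two groups at this position, with 3,5-dimethylphenyl on the sulfonyl sulfur. With the core held constant, the change on the sulfonyl sulfur from 4-methoxyphenyl to 3,5-dimethylphenyl gives a number 18 percentage points higher from compound 2 to compound 4 (beyond the scatter) while the change from 4-fluorophenyl to 3,5-dimethylphenyl gives a number 10 percentage points lower from compound 1 to compound 4 (within the scatter) and so places compound 4 with compound 1, apart from compound 2. Nothing at hand accounts for these steps.

Open, on these data alone, is whether a hydroxyl, an amine or a longer alkoxy chain at the core position would keep the number in this range. Also open, as far as these compounds go, is whether methoxy and methyl stay indistinguishable there with 4-fluorophenyl on the sulfonyl sulfur.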